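The source may report more compounds than this note shows. Statements on the series, on what has been measured and on what is new or still open speak of the compounds shown alone.

Measured compounds:
compound 1 `O=C(N/N=C/c1cccc(Br)c1)Nc1cc2c(Nc3ccc(F)c(Cl)c3)ncnc2cc1O[C@H]1CCOC1` — 32300 nM
compound 2 `CCN(CC)c1ccc(/C=N/NC(=O)Nc2cc3c(Nc4ccc(F)c(Cl)c4)ncnc3cc2O[C@H]2CCOC2)c(O)c1` — 15700 nM

In a functional assay on HepG2 cells (Homo sapiens) for cytotoxicity, read by MTT assay, with a stated time of 72 h (a higher number here means a weaker inhibitor, a lower number a stronger inhibitor), compound 1 gives 32300 nM, the highest of the two numbers; compound 2 gives 15700 nM, a modest step down of a 2.1-fold lower number from compound 1 to compound 2 (0.31 log units; beyond the scatter). Compound 3 `O=C(N/N=C/c1ccc(O)cc1)Nc1cc2c(Nc3ccc(F)c(Cl)c3)ncnc2cc1O[C@H]1CCOC1` differs from compound 1 by 4-hydroxyphenyl in place of 3-bromophenyl on a carbon with a double bond to nitrogen. Going by the values given here, the one step that bears on this is a 2.1-fold lower number from compound 1 to compound 2 (0.31 log units; beyond the scatter), where the 3-bromophenyl was likewise replaced by a hydroxy-bearing ring and the number fell only modestly. A similar small lowering, or none beyond the scatter, is therefore expected, giving a 1.5-fold lower number from compound 1 to compound 3 (0.17 log units; within the scatter). Compound 3 is estimated at 22000 nM, within 10000 nM to 50000 nM.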

Compound 3, half-maximal inhibitory concentration: 70 nM
The estimate for compound 3 lay 310-fold (2.50 log units) above the measured number; measured number below the stated range.
By their numbers in this assay, from the lowest: compound 3; then compound 2; then compound 1.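

In this assay, the group on the carbon with a double bond to nitrogen can shift the number far more than the earlier pair suggested: 4-hydroxyphenyl gives a 460-fold lower number from compound 1 to compound 3 (2.66 log units; beyond the scatter) in place of 3-bromophenyl and a 220-fold lower number from compound 2 to compound 3 (2.35 log units; beyond the scatter) in place of 4-(diethylamino)-2-hydroxyphenyl. A hydroxy group on the ring does not by itself bring this drop, as compound 2 also carries one and its number stays far higher. No measurement offered here accounts for the gap. The compounds shown leave open whether a 4-methoxyphenyl or 4-aminophenyl ring at this place would keep the low number.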